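The source may report more compounds than this note shows. Statements on the series, on what has been measured and on what is new or still open speak of the compounds shown alone.

Compound 2 `ClCc1ccccc1Cn1cnc2c(Cl)nc(Cl)nc21` stands lowest of the two numbers measured in a functional assay on 786-0 cells (Homo sapiens) for cytotoxicity, read by sulforhodamine B assay, with a stated time of 48 h; on this read-out higher numbers stand for lower toxicity in this test and lower numbers for higher toxicity in this test: in that test compound 2 gives 6450 nM. Among the compounds with values here, the other measured compound, compound 1 `ClCc1ccc(Cn2cnc3c(Cl)ncnc32)cc1`, gives 21400 nM in this assay, a higher number; the two compounds differ in more than one place, so no single step connects them. Compound 3 `ClCc1ccccc1Cn1cnc2c(Cl)ncnc21` is reached from compound 2 by hydrogen in place of chloro on an aromatic carbon between two ring nitrogen atoms. Within the data shown here, no measured pair shows this change on its own. Compound 3 carries the same single chloro on the core as compound 1, whose 21400 nM is the higher of the two measured values, so a move toward a higher number from compound 2, beyond the scatter, is expected. Compound 3 is therefore expected to give about 15000 nM, within 5000 nM to 45000 nM. This amounts to an expected step of a 2.3-fold higher number from compound 2 to compound 3 (0.37 log units; beyond the scatter).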

Compound 3, concentration lethal to 50% of the cells: 83200 nM
Compound 3: middle estimate off by 5.5-fold (0.74 log units), on the low side, outside the stated range (above it).
By their numbers in this assay, from the lowest: compound 2; then compound 1; then compound 3.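

Hydrogen in place of chloro on the aromatic carbon between two ring nitrogen atoms gives a 13-fold higher number from compound 2 to compound 3 (1.11 log units; beyond the scatter) in this assay, so this single position carries a large part of the read-out. The earlier pair differed in more than one place and could not isolate this position, whereas here, with the rest of the structure unchanged, the chloro goes with the lower number and therefore with higher toxicity in this test. Nothing among the available measurements gives a reason for the size of this step.

On these data alone, it remains open whether an amine, a methoxy group or a fluoro on this same carbon would give a number nearer that of compound 2 or that of compound 3. As far as these compounds go, it is also open whether this step would keep its size with the chloro group on the other aromatic carbon of the shared core changed.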